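Swapping bromo for methoxy on a hydroxyphenyl ring

A few compounds are considered here, and "the series" means these few. Any claim that something is new, unique, unknown or untested is made for them only; others in the source may bear on it.

Measured in a functional assay on SW480 cells (Homo sapiens) for antiproliferative activity, read by sulforhodamine B assay, with a stated time of 48 h; a lower number here means a stronger inhibitor, a higher number a weaker inhibitor:
- Compound 1 `COc1cc(OC)c(/C=C/C(=O)C(=Cc2ccc(O)c(F)c2)C(=O)/C=C/c2c(OC)cc(OC)cc2OC)c(OC)c1`: 1950 nM
- Compound 2 `COc1cc(OC)c(/C=C/C(=O)C(=Cc2cc(Br)c(O)c(OC)c2)C(=O)/C=C/c2c(OC)cc(OC)cc2OC)c(OC)c1`: 1450 nM

For the measured compounds named here, compound 2 and compound 1 are the only measured compounds so far, and their values are too close to rank them. The next compound, compound 3 `COc1cc(OC)c(/C=C/C(=O)C(=Cc2cc(OC)c(O)c(OC)c2)C(=O)/C=C/c2c(OC)cc(OC)cc2OC)c(OC)c1`, has methoxy in place of bromo on an aromatic carbon, so 3-bromo-4-hydroxy-5-methoxyphenyl becomes 4-hydroxy-3,5-dimethoxyphenyl: methoxy in place of bromo on an aromatic carbon. Going by the values given here, the one measured step that bears on this is a 1.3-fold lower number from compound 1 to compound 2 (0.13 log units; within the scatter), which was also an exchange of groups on that aromatic ring. A single step is thin evidence, but it gives no reason to expect a large shift. The expected result in this assay is no change beyond the scatter, a 1.0-fold lower number from compound 2 to compound 3 (0.02 log units; within the scatter). For compound 3 the estimate is 1400 nM, with an expected range of 650 nM to 3000 nM.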

Compound 3, half-maximal inhibitory concentration: 980 nM
Estimate against measurement, compound 3: 1.4-fold (0.15 log units) above; the measured number falls inside the stated range.
By their numbers in this assay, from the lowest: compounds 3, 2 and 1 (each within the scatter of the next).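

In this assay the position ortho to a hydroxy group takes methoxy in place of bromo with a 1.5-fold lower number from compound 2 to compound 3 (0.17 log units; within the scatter) and no shift beyond the scatter, although methoxy counts a hydrogen-bond acceptor and bromo counts none. The wider exchange of the whole ring gives a 2.0-fold lower number from compound 1 to compound 3 (0.30 log units; within the scatter) and also stays within the scatter, so this assay does not separate the three rings shown. No measurement shown explains why these numbers lie so close.

Going by these compounds, it remains open whether this position would keep such numbers with a group of another kind, such as an amine, a carboxylic acid or a longer alkoxy chain. Every ring shown also carries a hydroxy group, so whether that group is needed is equally open.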